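Cinnamate esters: a chlorophenyl variant of compound 1

The source may report more compounds than this note shows. Statements on the series, on what has been measured and on what is new or still open speak of the compounds shown alone.

Measured so far:
compound 1, `COc1cc(OC)c(OC)cc1/C=C/COC(=O)/C=C/c1ccc(OC)c(OC)c1`: 0%
compound 2, `COc1cc(OC)c(OC)cc1/C=C/COC(=O)/C=C/c1c(OC)ccc(OC)c1OC`: 50%
compound 3, `COc1cc(OC)c(OC)cc1/C=C/COC(=O)/C=C/c1ccc(OC)c(OC)c1OC`: 25%

In a functional assay on the whole organism (strain Kunming) with Mus musculus as the target, with a stated time of 0.5 h, at a dose of 300 mg/kg by the intraperitoneal route (on this read-out lower numbers stand for a stronger effect and higher numbers for a weaker effect at the one dose given), compound 1 gives the lowest of the three numbers. Compound 3 stands nearest to it, with a number 25 percentage points higher from compound 1 to compound 3 (beyond the scatter); compound 2 stands furthest away, its value being the highest of the three. Among the measured compounds shown here, the only single-point step within the measured set is therefore the one from compound 1 to compound 3, and it points toward a weaker effect when a methoxy group is added.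

Compound 4, `COc1cc(OC)c(OC)cc1/C=C/COC(=O)/C=C/c1ccccc1Cl`, differs from compound 1 in one place: 2-chlorophenyl in place of 3,4-dimethoxyphenyl on a double-bonded chain carbon bound to a double-bonded chain carbon. For the measured compounds named here, no measured step bears directly on this change. The step from compound 1 to compound 3 concerns an added methoxy group on the same ring, whereas here the two methoxy groups leave and a chlorine enters, so it gives only a loose hint that altering this ring moves the number away from that of compound 1. Since compound 1 already sits at the bottom of the read-out, any change beyond the scatter can only appear as a higher number.

For compound 4 a value of 20% is expected, within 0% to 55%, meaning an expected step of a number 20 percentage points higher from compound 1 to compound 4 (beyond the scatter).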

Compound 4, a percentage reported as activity, at one dose (the size of the read-out at that dose, not a potency): 25%
Compound 4: middle estimate off by 5 percentage points, on the low side; the range from low to high includes it.
By their numbers in this assay, from the lowest: compound 1; then compounds 3 and 4 (each within the scatter of the next); then compound 2.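

In this assay, a number 25 percentage points higher from compound 1 to compound 4 (beyond the scatter), so replacing 3,4-dimethoxyphenyl with 2-chlorophenyl on a double-bonded chain carbon bound to a double-bonded chain carbon points toward a weaker effect. Until now, this ring had been seen only carrying methoxy groups; compound 4 extends the series to a ring with no methoxy group and with chlorine instead, and the shift stays modest, with an entering group that has no hydrogen-bond acceptors in place of a leaving group that has 2. The data offer no independent measurement that would account for this step.

The single swap removes both methoxy groups and introduces chlorine at once, so the compounds shown do not separate the contribution of losing the methoxy groups from that of gaining the chlorine. Going by these compounds, an unsubstituted phenyl, a ring with a single methoxy group, or a ring bearing an amine or a carboxylic acid at this place would help to tell these contributions apart, and whether any such group can match compound 1 remains open.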